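Three Limits and One Open Step

This account rests on a few compounds, and the source may have more. Where it says the series, first, only, none or still open, it means among the compounds named here.

Measured so far in an ADME assay on HepG2 cells (Homo sapiens) for cytotoxicity, with a stated time of 72 h (on this read-out higher numbers stand for an effect only at larger amounts of compound and lower numbers for an effect already at smaller amounts), each value a limit:
- compound 1 `Cc1ccc(NC(=O)Nc2cc(C)nc3ccccc23)cc1` gives > 25000 nM as a limit
- compound 2 `Cc1cc(NC(=O)Nc2ccc(F)cc2)c2ccccc2n1` gives > 25000 nM as a limit
- compound 3 `Cc1cc(NC(=O)Nc2ccc(C(N)=O)cc2)c2ccccc2n1` gives > 25000 nM as a limit

Compound 3 stands at > 25000 nM, which is a limit and not a number. The same holds across the series, with the limit of > 25000 nM in this assay, at which 3 of the 3 values shown sit, as the whole picture so far.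

Among the compounds with values here, the next structure is compound 4 `Cc1cc(NC(=O)Nc2ccc(SC(F)(F)F)cc2)c2ccccc2n1`, which has (trifluoromethyl)sulfanyl in place of carbamoyl on an aromatic carbon as its one change.

Three measured swaps of a group on an aromatic carbon bear on this: a step that the two limits leave unreadable from compound 1 to compound 2, a step that the two limits leave unreadable from compound 1 to compound 3 and a step that the two limits leave unreadable from compound 2 to compound 3. None has a readable size, so none of them sets a size for the new step. No step beyond the scatter can therefore be predicted, although any readable value would have to lie toward smaller numbers.

The expected outcome is a number no higher from compound 3 to compound 4 (the limit leaves the size open) as an estimate. For compound 4 the estimated value is 25000 nM, with an expected range from 8000 nM to 50000 nM in this assay as the read-out.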

Compound 4, half-maximal effective concentration: 20000 nM
Beside the measured number, compound 4's estimate is 1.3-fold (0.10 log units) above it, within the range that was stated.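

Within the data shown here, compound 4, with (trifluoromethyl)sulfanyl on the aromatic carbon para to a large group, is the first compound in this assay to give a number and not a limit, so a change at this position can reach a readable value. Set against the earlier compounds, it shows an at least 1.2-fold lower number from compound 3 to compound 4 (0.09 log units; that floor lies within the scatter), an at least 1.2-fold lower number from compound 2 to compound 4 (0.09 log units; that floor lies within the scatter) and an at least 1.2-fold lower number from compound 1 to compound 4 (0.09 log units; that floor lies within the scatter), so each step is only a floor and none is shown to pass the scatter. Compound 1, compound 2 and compound 3 each remain a limit, so the true size of these steps stays unknown: the limit of > 25000 nM in this assay, at which 3 of the 4 values shown sit.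

The compounds shown leave open whether an amine, a carboxylic acid or a trifluoromethyl group at this position would also give a number. They also leave open whether a longer chain in place of the (trifluoromethyl)sulfanyl would give a lower one.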